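A few compounds are considered here, and "the series" means these few. Any claim that something is new, unique, unknown or untested is made for them only; others in the source may bear on it.

Measured so far:
compound 1 `COCCOCCCCc1[nH]c2ccccc2c(=O)c1C` — an in vitro ADME assay on microsomes from liver (Homo sapiens) for metabolic stability, tested at 0.2 uM; a lower number here means slower removal, a higher number faster removal of the compound: 45 mL/min/kg
compound 2 `COC(C)(C)CCOc1cccc(OCc2[nH]c3ccccc3c(=O)c2C)c1` — > 1000 mL/min/kg
compound 3 `CC(C)c1c(COc2cccc(OCC3CCOCC3)c2)[nH]c2ccccc2c1=O` — "not determined" (no result reported)

The value given for compound 2 is a limit of this assay, not a number: the limit of > 1000 mL/min/kg in this assay, at which 1 of the 3 values shown sits. Compound 2 is the one entry of the three that sits at that limit; compound 3 carries no number at all. Compound 4 `CCCCOc1cccc(OCc2[nH]c3ccccc3c(=O)c2C)c1` is not yet measured. The change from compound 2 to compound 4 is ethyl in place of 1-methoxy-1-methylethyl on a saturated chain carbon, two bonds along the chain from an oxygen on an aromatic ring. Going by the values given here, no measured pair shows this same change, so its size is unknown. Since compound 2 already sits at a limit, the expected step is an at least 1.4-fold lower number from compound 2 to compound 4 (0.15 log units; that floor lies within the scatter), downward if anything, though a second limit is quite possible. Compound 4 is estimated at 700 mL/min/kg in this assay, between 250 mL/min/kg and 1500 mL/min/kg.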

Compound 4, clearance in the Homo sapiens assay: > 1000 mL/min/kg
Compound 4 gave a limit, no number; the forecaster's own chance of this, stated with the estimate: 40%; at least 1.4-fold (0.15 log units) between middle value and limit.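

Compound 2 and compound 4 both sit at a limit in the Homo sapiens assay, so no step between them can be read: the limit of > 1000 mL/min/kg in the Homo sapiens assay, at which 2 of the 4 values shown sit.

In a physicochemical assay for solubility, at pH 6.8 (on this read-out higher numbers stand for higher solubility and lower numbers for lower solubility), compound 2 gives 2000 nM. In the physicochemical assay compound 4 gives < 1000 nM, which is a limit of the assay, not a number.

The compounds shown leave open whether clearance differs at all between the 3-methoxy-3-methylbutoxy and butoxy compounds.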